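Methoxy-to-fluoro exchange repeated on a second core

The source may report more compounds than this note shows. Statements on the series, on what has been measured and on what is new or still open speak of the compounds shown alone.

Compound 1 `COc1ccc(C2=Nn3c(nnc3C(C)c3ccc(-c4ccccc4)c(F)c3)SC2)cc1` and compound 3 `COc1ccc(C2=Nn3c(nnc3C(C)c3ccc(CC(C)C)cc3)SC2)cc1` both carry a methoxy-bearing aryl group; how their two cores differ is not broken down here. In a functional assay on Huh-7 cells (Homo sapiens) for inhibition, read by sulforhodamine B assay, with a stated time of 72 h (a lower number here means a stronger inhibitor, a higher number a weaker inhibitor), compound 1 gives 4300 nM and compound 3 gives 3700 nM, two values that lie within the scatter of each other. Compound 2 `CC(c1ccc(-c2ccccc2)c(F)c1)c1nnc2n1N=C(c1ccc(F)cc1)CS2` is compound 1 after one change, (fluoro in place of methoxy on an aromatic carbon). In this assay compound 2 gives 4900 nM, so the change brought a 1.1-fold higher number from compound 1 to compound 2 (0.06 log units; within the scatter). Compound 4 `CC(C)Cc1ccc(C(C)c2nnc3n2N=C(c2ccc(F)cc2)CS3)cc1` stands to compound 3 as compound 2 stands to compound 1: the change is fluoro in place of methoxy on an aromatic carbon, the same change at a place described in the same words, made on the core of compound 3 instead of the core of compound 1. Compound 4 has not yet been measured in this assay. The expected step is a 1.1-fold higher number from compound 3 to compound 4 (0.04 log units; within the scatter), because a 1.1-fold higher number from compound 1 to compound 2 (0.06 log units; within the scatter) stayed within the scatter. The starting points are also alike, since compound 3 gives 3700 nM while compound 1 gives 4300 nM, so nothing in the measured pair suggests the second core should answer the change differently. For the measured compounds named here, only one measured instance of the change exists, so the expectation rests on a single pair. Compound 4 is therefore expected to give about 4100 nM in this assay, with 2000 nM and 8500 nM as the expected ends of the range.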

Compound 4, half-maximal inhibitory concentration: 7800 nM
For compound 4 the middle estimate is 1.9-fold (0.28 log units) below the measured one; low and high end bracket the measured number.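

On the second core, the exchange of 4-methoxyphenyl for 4-fluorophenyl in this assay brought a 2.1-fold higher number from compound 3 to compound 4 (0.32 log units; beyond the scatter), a modest step. Set beside the first instance of the change, this step does not differ from it by more than two such steps can scatter: the same change on two cores in this assay, a 1.1-fold higher number (0.06 log units; within the scatter) from compound 1 to compound 2 and a 2.1-fold higher number (0.32 log units; beyond the scatter) from compound 3 to compound 4, 1.8-fold (0.27 log units) apart, within the scatter of two such steps The two pairs therefore give no sign that the core alters the outcome of the change, although only the step on the second core lies beyond the scatter, and with just two pairs they neither establish that the change carries over to other cores nor show why the steps take the sizes they do.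

The compounds shown carry only methoxy or fluoro in this place on the aromatic ring, so it remains open how an amine, a carboxylic acid or a longer chain such as butoxy would read in this assay. From the compounds shown here alone, whether the exchange of methoxy for fluoro would give a step of similar size on a third core also remains open.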